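A few compounds are considered here, and "the series" means these few. Any claim that something is new, unique, unknown or untested is made for them only; others in the source may bear on it.

Notes on a series built around the shared core of compound 1 `Clc1ccc2c(NCCNc3nccc(Nc4ccccc4)n3)ccnc2c1`, which in an ADME assay on Vero cells (Chlorocebus sabaeus) for cytotoxicity, read by neutral red uptake, with a stated time of 72 h (on this read-out higher numbers stand for weaker inhibition and lower numbers for stronger inhibition), gives "not active" (no number reported), an entry with no number reported. Compound 2 `Cc1ccc(Nc2ccnc(NCCNc3ccnc4cc(Cl)ccc34)n2)cc1` gives 13600 nM in this assay. Compound 3 `Clc1ccc2c(NCCCCNc3nccc(Nc4ccccc4)n3)ccnc2c1` gives 14300 nM in this assay. Of the two values reported as numbers, compound 3 holds the higher one, but its gap to compound 2 lies within the usual scatter of repeated measurements, so no order between these two can be read from this assay; compound 1 stands apart as an entry without a number.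

Compound 4 `Clc1ccc2c(NCCCCNc3nccc(Nc4ccc(Br)cc4)n3)ccnc2c1` has not yet been measured in this assay. It differs from compound 3 by bromo in place of hydrogen on an aromatic carbon, which reads as bromo in place of hydrogen on an aromatic carbon, para to a large group. Among the measured compounds shown here, no pair of measured compounds carries this same change, so there is no measured step to draw on. For compound 4 the change is expected to move the number in this assay by no more than the scatter, with no direction to call, and the expected step is a 1.2-fold lower number from compound 3 to compound 4 (0.08 log units; within the scatter). Compound 4 is expected to give 12000 nM in this assay, with a range from 6000 nM to 25000 nM.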

Compound 4, half-maximal inhibitory concentration: 10000 nM
Beside the measured number, compound 4's estimate is 1.2-fold (0.08 log units) above it; the measured number falls inside the stated range.
By their numbers in this assay, from the lowest: compounds 4, 2 and 3 (each within the scatter of the next).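

In this assay, among the compounds shown here, the move from phenyl to 4-bromophenyl gives a 1.4-fold lower number from compound 3 to compound 4 (0.16 log units; within the scatter) and so provides the first step that can be read for a single change. It shows that, on the chain of compound 3, this aromatic carbon para to a large group can carry a bromo with no difference that can be read from this assay, so this one substitution gives no sign that the position governs the number. No measurement shown here offers an explanation for this result.

As far as these compounds go, this single step covers one group at one place, so whether a carboxylic acid, a dimethylamino group or a morpholine ring on the same carbon would give a step beyond the scatter remains open. Also open, from the compounds shown here alone, is whether the bromo would behave in the same way on the chain of compound 1, whose entry carries no number, or on a longer chain than that of compound 3.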